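Swapping a Methyl for a Tert-Butyl on the Pendant Ring

The source may report more compounds than this note shows. Statements on the series, on what has been measured and on what is new or still open speak of the compounds shown alone.

Of the compounds shown here, two sharing one core have been tested in a functional assay on HCT-116 cells (Homo sapiens) for inhibition, read by CCK-8 assay, with a stated time of 48 h; on this read-out lower numbers stand for stronger inhibition and higher numbers for weaker inhibition. Compound 1 `COc1cc(-c2ccnc3cc(-c4ccc(N(C)C)cc4)nn23)cc(OC)c1OC` carries a 4-(dimethylamino)phenyl group and gives 2050 nM. Within the data shown here, compound 2 `COc1cc(-c2ccnc3cc(-c4cccc(C)c4)nn23)cc(OC)c1OC` carries a 3-methylphenyl group instead and gives 6150 nM, the higher of the two numbers and thus the weaker inhibitor here; the only measured step, a 3.0-fold higher number from compound 1 to compound 2 (0.48 log units; beyond the scatter), is beyond the scatter.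

Compound 3 `COc1cc(-c2ccnc3cc(-c4ccc(C(C)(C)C)cc4)nn23)cc(OC)c1OC` has not yet been measured. It differs from compound 2 in one place: 4-(tert-butyl)phenyl in place of 3-methylphenyl on an aromatic carbon. Among the measured compounds shown here, the one measured step bears only loosely on this change, since it compares a 4-(dimethylamino)phenyl with a 3-methylphenyl, while the new group is a 4-(tert-butyl)phenyl, with neither of those features in common. The step from compound 1 to compound 2 shows that changing this pendant ring can move this assay by a modest amount, so a change of similar size, in either direction, seems plausible for compound 3.

Compound 3 is therefore expected to give about 4500 nM, within roughly 1500 nM to 14000 nM, which would mean an estimated step of a 1.4-fold lower number from compound 2 to compound 3 (0.14 log units; within the scatter).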

Compound 3, half-maximal inhibitory concentration: > 10000 nM
Compound 3 gave a limit, no number; the forecaster's own chance of this, stated with the estimate: 10%; middle value at least 2.2-fold (0.34 log units) away from the limit.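

Compound 3 reaches only a limit, not a number, in this assay: the limit of > 10000 nM in this assay, at which 1 of the 3 values shown sits.

Against the 3-methylphenyl group, the new 4-(tert-butyl)phenyl group gives an at least 1.6-fold higher number from compound 2 to compound 3 (0.21 log units; that floor lies within the scatter), so this floor alone does not set the two compounds apart. Against the dimethylamino group, tert-butyl gives an at least 4.8-fold higher number from compound 1 to compound 3 (0.68 log units; beyond the scatter), which shows that the second change on the pendant ring does move the read-out clearly. Compound 1, with steps beyond the scatter to both other compounds, therefore stands as the strongest of the three, and neither group made only of carbon on this ring comes close to it.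

The limit hides the true value of compound 3, so how far it lies from compound 2 cannot be read. Going by these compounds, whether a primary amine, a morpholine or a methoxy group on the pendant ring would match compound 1 or fall back towards the other two stays open, as does the result of moving the dimethylamino group elsewhere on that ring.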